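The source may report more compounds than this note shows. Statements on the series, on what has been measured and on what is new or still open speak of the compounds shown alone.

Within the data shown here, compound 1 `COc1ccc([C@@H](O)COC(=O)/C=C/c2ccccc2)cc1OC` gives 5870 nM in an ADME assay on Vero cells (Chlorocebus sabaeus) for cytotoxicity, read by MTT assay, with a stated time of 72 h (on this read-out higher numbers stand for lower toxicity in this test and lower numbers for higher toxicity in this test), the lowest of the three numbers measured so far. Compound 3 `COc1ccccc1[C@H](O)COC(=O)/C=C/c1ccccc1` gives 14000 nM, and compound 2 `COc1cc([C@@H](O)COC(=O)/C=C/c2ccccc2)cc(OC)c1OC` gives 122000 nM.

The next compound, compound 4 `COc1cccc([C@@H](O)COC(=O)/C=C/c2ccccc2)c1`, departs from compound 1 by one exchange: hydrogen in place of methoxy on an aromatic carbon. This is hydrogen in place of methoxy on an aromatic carbon, para to a large group and ortho to a methoxy group.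

Among the measured compounds shown here, the one measured step of this kind is a 21-fold higher number from compound 1 to compound 2 (1.32 log units; beyond the scatter), a large step beyond the scatter, with methoxy in place of hydrogen on an aromatic carbon. It runs in the opposite sense and not at the same place. Taken alone, it would point to a lower number for compound 4.

Against that reading, a compound with fewer methoxy groups than compound 1 does not lie lower: compound 3 stands at 14000 nM. Compound 1 already holds the lowest number, so the evidence favours a modest rise in this assay, near the edge of the scatter, over a further fall.

The expected change is a 1.9-fold higher number from compound 1 to compound 4 (0.27 log units; within the scatter). For compound 4 the estimate is 11000 nM, with an expected range from 3500 nM to 35000 nM.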

Compound 4, half-maximal cytotoxic concentration: 22300 nM
Compound 4: middle estimate off by 2.0-fold (0.31 log units), on the low side; the range from low to high includes it.
By their numbers in this assay, from the lowest: compound 1; then compounds 3 and 4 (each within the scatter of the next); then compound 2.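

In this assay, the exchange of methoxy for hydrogen at this place, ortho to a methoxy group and para to a large group, gives a 3.8-fold higher number from compound 1 to compound 4 (0.58 log units; beyond the scatter), so a methoxy group here is not needed to keep the number high and its loss moves the number upward. Read with a 21-fold higher number from compound 1 to compound 2 (1.32 log units; beyond the scatter), a step at a different place that adds a methoxy group, it shows that a single exchange in either direction leaves compound 1 with the lower number, and the count of methoxy groups does not put compound 4, compound 1 and compound 2 in a simple order. Nothing measured here gives a reason for this behaviour.

The compounds shown leave open whether the higher number comes from the loss of methoxy as such or would also appear with another group at this place, such as fluorine, a hydroxy group or an amine. They also leave open whether replacing the other methoxy group of compound 1 with hydrogen would give a step of similar size.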